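This account rests on a few compounds, and the source may have more. Where it says the series, first, only, none or still open, it means among the compounds named here.

Series notes, cytotoxicity set. Compound 1 `CC1Cn2c(nc([N+](=O)[O-])c2-c2ccc(CO)cc2)O1` and compound 2 `Cc1ccc(-c2c([N+](=O)[O-])nc3n2CC(C)O3)cc1` share a core, while the difference between the core of compound 2 and that of compound 3 `Cc1ccc(C#Cc2c([N+](=O)[O-])nc3n2CC(C)O3)cc1` is not broken down here. In an ADME assay on CHO cells (Cricetulus griseus) for cytotoxicity, read by MTT assay, with a stated time of 24 h (a lower number here means that less compound is tolerated, a higher number that more compound is tolerated), compound 1 reports only a limit, > 500000 nM. In this assay compound 2 likewise reports only a limit, > 250000 nM. Going by the values given here, compound 3 is the single compound with a number, giving 5470 nM in this assay. The change from compound 2 to compound 1 hydroxy in place of hydrogen on a saturated chain carbon bound to an aromatic carbon gives a step that the two limits leave unreadable from compound 2 to compound 1, the two limits the limit of > 250000 nM in this assay, at which 1 of the 3 values shown sits, and the limit of > 500000 nM in this assay, at which 1 of the 3 values shown sits, leaving it unreadable. Compound 4 `CC1Cn2c(nc([N+](=O)[O-])c2C#Cc2ccc(CO)cc2)O1` carries the same kind of change from compound 3 (hydroxy in place of hydrogen on a saturated chain carbon bound to an aromatic carbon). With no readable precedent, the expected step of a 1.5-fold higher number from compound 3 to compound 4 (0.17 log units; within the scatter) is small, resting on compound 3 at 5470 nM as the only anchor. Compound 4 is expected near 8000 nM, estimated between 3000 nM and 25000 nM.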

Compound 4, half-maximal cytotoxic concentration: 8770 nM
Beside the measured number, compound 4's estimate is 1.1-fold (0.04 log units) below it; measured number inside the range.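

In this assay, hydroxy in place of hydrogen on a saturated chain carbon bound to an aromatic carbon gives a 1.6-fold higher number from compound 3 to compound 4 (0.21 log units; within the scatter), so on the core of compound 3 the change has no effect separable from the scatter. On the core of compound 2, the same change gives no readable step, as the values of compound 1 and compound 2 are both limits of the assay. Carrying the change from one core to the other is therefore untested, since one readable step offers nothing to compare it with.

Open, as far as these compounds go, is how an amine or a carboxylic acid in place of the hydroxy would read in this assay. Also open, from the compounds shown here alone, is how a longer chain carrying the hydroxy would read there.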